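The source may report more compounds than this note shows. Statements on the series, on what has been measured and on what is new or still open speak of the compounds shown alone.

Compound 3 `CCOC(=O)N1CCC(Oc2cc(Oc3ccc(/C=C4\SC(=O)NC4=O)cc3)ncn2)CC1` gives the highest of the three numbers recorded in a functional assay on CHO-K1 cells for agonist activity at Glucose-dependent insulinotropic receptor (Homo sapiens), read by cAMP accumulation and immunoassay, with a stated time of 1 h; a higher number here means that more compound is needed for the effect, a lower number that less compound is needed: compound 3 gives 790 nM. The nearest of the others is compound 1 `CCOC(=O)N1CCC(Oc2ncnc(Oc3ccc(/C=C4\SC(=O)NC4=O)cc3)c2C)CC1`, which in this assay gives 157 nM; the furthest is compound 2 `Cc1c(Oc2ccc(/C=C3\SC(=O)NC3=O)cc2)ncnc1OC1CCN(C(=O)OCC(C)C)CC1`, which in this assay gives 75.1 nM. The step of a 5.0-fold higher number from compound 1 to compound 3 (0.70 log units; beyond the scatter) shows how much the loss of the aromatic methyl costs, and the step of a 2.1-fold lower number from compound 1 to compound 2 (0.32 log units; beyond the scatter) shows what a larger group on the carbamate side brings.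

Compound 4 `O=C1NC(=O)/C(=C/c2ccc(Oc3cc(OC4CCN(C(=O)OCc5ccccc5)CC4)ncn3)cc2)S1` keeps the core of compound 3 and differs from it only in one place: phenyl in place of methyl on a saturated chain carbon bound to an oxygen next to a carbonyl group. For the measured compounds named here, the one measured step that bears on this position is a 2.1-fold lower number from compound 1 to compound 2 (0.32 log units; beyond the scatter), a change at the same saturated chain carbon bound to an oxygen next to a carbonyl group, and it gave a modest lower number. Phenyl is a larger and different group than isopropyl, so the size of the effect cannot be read directly from that step, but its direction is the only guide available. Compound 4 is therefore expected to show a modest lower number than compound 3, estimated as a 2.0-fold lower number from compound 3 to compound 4 (0.30 log units; within the scatter), giving an expected value of 400 nM with a range from 150 nM to 1200 nM.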

Compound 4, half-maximal effective concentration: 107 nM
The estimate for compound 4 lay 3.7-fold (0.57 log units) above the measured number; measured number below the stated range.
By their numbers in this assay, from the lowest: compounds 2, 4 and 1 (each within the scatter of the next, the first and the last beyond it); then compound 3.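

At the saturated chain carbon bound to an oxygen next to a carbonyl group, the earlier compounds had shown only isopropyl in place of methyl, in the step of a 2.1-fold lower number from compound 1 to compound 2 (0.32 log units; beyond the scatter), and only on the core that carries the aromatic methyl. The new step, a 7.4-fold lower number from compound 3 to compound 4 (0.87 log units; beyond the scatter), shows that in this assay this place also accepts a six-membered aromatic ring of carbon only, turning ethoxycarbonyl into benzyloxycarbonyl, and that a lower number follows a larger group here on the core without the aromatic methyl as well, so both pairs with a change at this place point the same way. The data shown offer no measurement that would account for the size of this step.

Going by these compounds, it stays open whether benzyloxycarbonyl would give a comparable step on the core that keeps the aromatic methyl, and so whether the two changes would simply add up. On these data alone, it is equally open how this place would respond to a phenyl ring carrying a fluorine atom, a pyridine ring, a longer chain leading to the phenyl ring, or an amine at the end of the chain.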